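The compounds below may be only part of what the source reports. "The series", "measured", "known", "first", "only" and "open" are said of these compounds alone.

Measured so far:
compound 1, `O=C(CCc1nnc(-c2ccccc2Cl)o1)c1ccccc1` — in a functional assay on the whole organism (strain Wistar) for inhibition, with Rattus norvegicus as the target, with stated times of 30 min and 2 h, at a dose of 20 mg/kg by the oral route (on this read-out lower numbers stand for less inhibition and higher numbers for more inhibition at the one dose given (going by the name of the read-out)), compound 1 gives 26.9%
compound 2, `Cc1ccc(C(=O)CCc2nnc(-c3ccccc3)o2)c(C)c1` — in this assay compound 2 gives 36%

Compound 2 holds the higher of the two numbers in this assay, but compound 1 lies within the scatter of it, so no order between the two is read. Compound 3, `Cc1ccc(C(=O)CCc2nnc(-c3ccccc3Cl)o2)c(C)c1`, differs from compound 2 by chloro in place of hydrogen on an aromatic carbon, ortho to a large group. Going by the values given here, no step between measured compounds is available to size this change, so in this assay the expected step of a number 1 percentage points lower from compound 2 to compound 3 (within the scatter) stays within the scatter, with no direction beyond it. Compound 3 is expected to give 35%, estimated within 22% to 48%.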

Compound 3, a percentage reported as inhibition, in the whole organism at one dose (the size of the read-out at that dose, not a potency): 33.5%
The estimate for compound 3 lay 1.5 percentage points above the measured number; low and high end bracket the measured number.
By their numbers in this assay, from the lowest: compounds 1, 3 and 2 (each within the scatter of the next).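

In this assay chloro in place of hydrogen on an aromatic carbon, ortho to a large group, now has a measured size with the 2,4-dimethylphenyl group present (a number 2.5 percentage points lower from compound 2 to compound 3 (within the scatter)). With chloro kept, 2,4-dimethylphenyl in place of phenyl on a carbonyl carbon also has a measured size (a number 6.6 percentage points higher from compound 1 to compound 3 (within the scatter)). Neither change moves the read-out beyond the scatter, and nothing available offers a cause for either step.

Going by these compounds, whether an amine or a carboxylic acid in place of chloro at this position would give a step beyond the scatter remains open. The two compounds of this step also leave open how chloro behaves with other groups on the carbonyl carbon.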